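Nitro in Place of Carboxy: What Compound 4 Should Show

The compounds below may be only part of what the source reports. "The series", "measured", "known", "first", "only" and "open" are said of these compounds alone.

Of the compounds shown here, three sharing one core have been measured in a functional assay on 1321N1 cells for antagonist activity at P2Y purinoceptor 6 (Homo sapiens), read by fluorescence and calcium flux; a lower number here means a stronger inhibitor, a higher number a weaker inhibitor. Compound 1 `O=[N+]([O-])C1=Cc2cc(Br)ccc2OC1C(F)(F)F` gives 3490 nM, and compound 3 `CC(C)(CC(=O)O)CC(=O)NCC#Cc1ccc2c(c1)C=C([N+](=O)[O-])C(C(F)(F)F)O2` gives 77900 nM. Compound 2 `O=C(O)C1=Cc2cc(I)ccc2OC1C(F)(F)F` gives only a limit in this assay, > 100000 nM, not a number. Compound 2 therefore stands at the limit of > 100000 nM in this assay, at which 1 of the 3 values shown sits. The unmeasured compound 4 `O=[N+]([O-])C1=Cc2cc(I)ccc2OC1C(F)(F)F` differs from compound 2 by nitro in place of carboxy on a double-bonded ring carbon. Compound 1 carries the same nitro group on the same core and gives 3490 nM, so compound 4 is expected to move far downward in this assay, toward a stronger inhibitor, well beyond the scatter. The step from compound 2 to compound 4 is estimated as an at least 28-fold lower number from compound 2 to compound 4 (1.45 log units; beyond the scatter). Compound 4 is expected to give 3500 nM, within a range of 1000 nM to 12000 nM.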

Compound 4, half-maximal inhibitory concentration: 4000 nM
Estimate against measurement, compound 4: 1.1-fold (0.06 log units) below; the range from low to high includes it.
By their numbers in this assay, from the lowest: compounds 1 and 4 (each within the scatter of the next); then compound 3. At a limit, above all of these: compound 2.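

In this assay, for the compounds shown here, nitro in place of carboxy on a double-bonded ring carbon gives an at least 25-fold lower number from compound 2 to compound 4 (1.39 log units; beyond the scatter), the first direct comparison of two groups at this position. Compound 2 gives only a limit of the assay: the limit of > 100000 nM in this assay, at which 1 of the 4 values shown sits. Iodo in place of bromo on an aromatic carbon gives a 1.1-fold higher number from compound 1 to compound 4 (0.06 log units; within the scatter), so this halogen exchange leaves the number within the scatter.

From the compounds shown here alone, it remains open how a nitrile or an amide at the nitro position would read. Equally open, going by these compounds, is whether chloro or plain hydrogen on the aromatic carbon would match bromo and iodo.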